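The source may hold more compounds than are shown below. What is called first, only, known or untested is meant among the compounds shown, and "the series" means these compounds.

The measured compounds and their readings in a functional assay on MCF7 cells (Homo sapiens) for inhibition, read by MTT assay, with a stated time of 72 h, tested at 10 uM; a lower number here means less inhibition, a higher number more inhibition at the concentration tested (going by the name of the read-out):
Compound 1, `CCOC(=O)C1=C(Nc2ccccc2)S/C(=C\c2ccc(OC)cc2)C1=O`, gives 14.7%.
Compound 2, `CCOC(=O)C1=C(Nc2ccccc2)S/C(=C\c2cccc(C(=O)O)c2)C1=O`, gives < 10%; this is a limit of the assay, not a number (the limit of < 10% in this assay, at which 1 of the 3 values shown sits).
Compound 3, `CCOC(=O)C1=C(Nc2ccccc2)S/C(=C\c2ccc[nH]2)C1=O`, gives 18.3%.

Compound 3 stands highest of the two numbers reported in this assay; its nearest neighbour is compound 1, and the difference between them is small: a number 3.6 percentage points higher from compound 1 to compound 3 (within the scatter). The other steps among the measured compounds, a number at least 4.7 percentage points lower from compound 1 to compound 2 (that floor lies within the scatter) and a number at least 8.3 percentage points higher from compound 2 to compound 3 (that floor lies within the scatter), likewise stay within the scatter or rest on a limit, so the three compounds are not separated by this assay.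

Compound 4, `CCOC(=O)C1=C(Nc2cccc(F)c2)S/C(=C\c2ccc[nH]2)C1=O`, differs from compound 3 in one place: fluoro in place of hydrogen on an aromatic carbon. Among the compounds with values here, all the measured steps exchange the group on the double-bonded chain carbon and leave the anilino part untouched, so none of them bears directly on this change. What they do show is that the readings of this series remain close together across three different groups, and nothing in them points to a move beyond the scatter for a single fluoro added elsewhere.

Compound 4 is therefore expected to give about 18% in this assay, in the range from 8% to 30%. The step is estimated as a number 0.3 percentage points lower from compound 3 to compound 4 (within the scatter), which is no step beyond the scatter.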

Compound 4, a percentage reported as inhibition, at one concentration (the size of the read-out at that concentration, not a potency): < 10%
Compound 4: no number, only a limit (the forecaster's own chance of this, stated with the estimate: 20%); middle value at least 8 percentage points from the limit.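

Within the data shown here, the fluoro group is the first change in the anilino part, where phenyl becomes 3-fluorophenyl, whereas the earlier steps all exchanged the group on the double-bonded chain carbon. In this assay the step for this change on an aromatic carbon, meta to a large group, reads a number at least 8.3 percentage points lower from compound 3 to compound 4 (that floor lies within the scatter), so even this new place in the molecule gives no separation that can be called beyond the scatter. The reading of compound 4 is a limit of the assay and not a number, which leaves the true size of the step unknown, and it is the second reading of the series to stand there: the limit of < 10% in this assay, at which 2 of the 4 values shown sit.

The compounds shown leave open whether the anilino part matters at all in this assay, and whether another group on this ring, such as a methoxy group, a chlorine atom, an amine or a carboxylic acid, would give a reading that can be set as a number beside that of compound 3. Also open, going by these compounds, is whether fluoro on a different carbon of the same ring, or on a ring carrying a different group on the double-bonded chain carbon, would read as it does in compound 4.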